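Swapping an aryl for a chloropropyl on the triazole

The source may hold more compounds than are shown below. What is called first, only, known or untested is meant among the compounds shown, and "the series" means these compounds.

Measured so far in a functional assay on HCT-116 cells (Homo sapiens) for antiproliferative activity, read by MTT assay, with a stated time of 72 h; a higher number here means a weaker inhibitor, a lower number a stronger inhibitor:
- compound 1 `O=C1O/C(=C\Cn2cc(-c3ccc(Br)cc3)nn2)C(OCc2ccccc2)=C1OCc1ccccc1`, > 100000 nM.
- compound 2 `O=C1O/C(=C\Cn2cc(-c3cc(F)cc(F)c3)nn2)C(OCc2ccccc2)=C1OCc1ccccc1`, > 100000 nM.
- compound 3 `O=C1O[C@H]([C@@H](O)Cn2cc(-c3cccc(O)c3)nn2)C(OCc2ccccc2)=C1OCc1ccccc1`, 42900 nM.

The value of compound 1 is a limit of the assay. The value of compound 2 is also a limit. Compound 3 gives the only actual number shown; the step that the two limits leave unreadable from compound 1 to compound 2 cannot be read because of the limit of > 100000 nM in this assay, at which 2 of the 3 values shown sit. Compound 4 `O=C1O[C@H]([C@@H](O)Cn2cc(CCCCl)nn2)C(OCc2ccccc2)=C1OCc1ccccc1` differs from compound 3 by 3-chloropropyl in place of 3-hydroxyphenyl on an aromatic carbon. Among the measured compounds shown here, no measured step touches this kind of change, so nothing fixes its size or direction. Compound 3 already sits far up the scale, and compound 4 is expected to lie near it or beyond the limit, a step of a 1.9-fold higher number from compound 3 to compound 4 (0.27 log units; within the scatter). For compound 4 the estimate is 80000 nM, ranging from 20000 nM to 300000 nM.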

Compound 4, half-maximal inhibitory concentration: 36100 nM
Estimate against measurement, compound 4: 2.2-fold (0.35 log units) above; low and high end bracket the measured number.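

In this assay, among the compounds shown here, the step at this position is the first that can be read: a 1.2-fold lower number from compound 3 to compound 4 (0.07 log units; within the scatter). An open 3-chloropropyl chain, with no ring and no hydrogen-bond donor, therefore cannot be told apart from 3-hydroxyphenyl on the triazole of this core, so neither the aromatic ring nor its hydroxyl is required to hold the number at this level. The data at hand offer no explanation for this result.

Going by these compounds, whether an amine, a carboxylic acid or a longer chain at this position would shift the number beyond the scatter remains open. So does whether any group here can bring a much lower number.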